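Changing the amide substituent of compound 3

A few compounds are considered here, and "the series" means these few. Any claim that something is new, unique, unknown or untested is made for them only; others in the source may bear on it.

In a functional assay on MCF7 cells (Homo sapiens) for antiproliferative activity, read by MTT assay, with a stated time of 24 h (a lower number here means a stronger inhibitor, a higher number a weaker inhibitor), compound 1 `CCn1c(C(=O)NCCN)ccc1C(CC)(CC)c1ccc(OCS(=O)(=O)c2ccccc2)c(C)c1` gives 6470 nM and compound 2 `CCn1c(C(=O)N[C@H](C)CO)ccc1C(CC)(CC)c1ccc(OCS(=O)(=O)c2ccccc2)c(C)c1` gives 10600 nM while compound 3 `CCn1c(C(=O)N[C@@H](CO)C(C)C)ccc1C(CC)(CC)c1ccc(OCS(=O)(=O)c2ccccc2)c(C)c1` gives 18800 nM on the shared core. Against its neighbours there is a 2.9-fold higher number from compound 1 to compound 3 (0.46 log units; beyond the scatter) and there is a 1.8-fold higher number from compound 2 to compound 3 (0.25 log units; within the scatter) so compound 3 stands clear of compound 1 only.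

Going by the values given here, compound 4 `CCn1c(C(=O)N[C@H](CO)CCO)ccc1C(CC)(CC)c1ccc(OCS(=O)(=O)c2ccccc2)c(C)c1` carries 3-hydroxy-1-(hydroxymethyl)propyl in place of 1-(hydroxymethyl)-2-methylpropyl on an amide-type nitrogen and no measured step makes this exact exchange. The nearest evidence is the other changes on that nitrogen, where the remaining step is a 1.6-fold higher number from compound 1 to compound 2 (0.21 log units; within the scatter) and all three stay small. Here 1-(hydroxymethyl)-2-methylpropyl leaves, and it is the group that arrives in a 1.8-fold higher number from compound 2 to compound 3 (0.25 log units; within the scatter) so a small move towards a lower number is expected in this assay with nothing beyond the scatter. The expected step is a 1.4-fold lower number from compound 3 to compound 4 (0.16 log units; within the scatter) on this estimate. For compound 4 the estimated value is 13000 nM with an expected range from 6000 nM to 28000 nM in this series.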

Compound 4, half-maximal inhibitory concentration: 28500 nM
Compound 4: the middle estimate sits 2.2-fold (0.34 log units) below what was measured; measured number above the stated range.
By their numbers in this assay, from the lowest: compounds 1, 2, 3 and 4 (each within the scatter of the next, the first and the last beyond it).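

In this assay, the exchange of 1-(hydroxymethyl)-2-methylpropyl for 3-hydroxy-1-(hydroxymethyl)propyl on the amide-type nitrogen reads as a 1.5-fold higher number from compound 3 to compound 4 (0.18 log units; within the scatter), so these two groups are not told apart at this position. The other two new steps are larger: a 2.7-fold higher number from compound 2 to compound 4 (0.43 log units; beyond the scatter) and a 4.4-fold higher number from compound 1 to compound 4 (0.64 log units; beyond the scatter). Compound 4 therefore stands clear of compound 2, which compound 3 does not, and it stands clear of compound 1, as compound 3 does. No supporting evidence bears on these steps, so they remain observations only.

As far as these compounds go, it remains open whether the amine of 2-aminoethyl is what sets compound 1 apart from compound 4, or whether a carboxylic acid or a longer hydroxyalkyl chain on this nitrogen would fit the same pattern. The opposite configuration at the defined stereocentre of 3-hydroxy-1-(hydroxymethyl)propyl is also an open question.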